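The source may report more compounds than this note shows. Statements on the series, on what has been measured and on what is new or still open speak of the compounds shown alone.

In a functional assay on CLL cells (Homo sapiens) for cytotoxicity, read by MTT assay, with a stated time of 48 h (on this read-out higher numbers stand for an effect only at larger amounts of compound and lower numbers for an effect already at smaller amounts), compound 1 `C=C(CC)C(=O)c1ccc(OCC(=O)NCC(=O)O)c(Cl)c1Cl` reads > 25000 nM as its result, which is a limit of the assay and not a number. Within the data shown here, compound 2 `C=C(CC)C(=O)c1ccc(OCC(=O)Nc2ccc(/C=C/C(=O)OCC)cc2)c(Cl)c1Cl` gives 1700 nM in this assay and so holds the only true number available so far, which leaves little to rank it against.

Compound 3 `C=C(CC)C(=O)c1ccc(OCC(=O)Nc2ccc(C(C)=O)cc2)c(Cl)c1Cl` keeps the core of compound 2 and changes one group: acetyl in place of 2-(ethoxycarbonyl)ethenyl on an aromatic carbon is the whole difference. Put simply, acetyl takes the place of 2-(ethoxycarbonyl)ethenyl on an aromatic carbon, para to a large group.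

Among the measured compounds shown here, no measured pair shows what this exchange does, so the size of the step is a matter of judgement. The rest of compound 2 at 1700 nM stays untouched, which points to a moderate shift toward higher numbers. The expected change is a 2.1-fold higher number from compound 2 to compound 3 (0.31 log units; beyond the scatter) in this estimate, a modest loss of effect that may not lie far beyond the usual scatter. Compound 3 is estimated at 3500 nM in this assay with an expected range from 1300 nM to 11000 nM for its measured value.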

Compound 3, half-maximal effective concentration: 3900 nM
For compound 3 the middle estimate is 1.1-fold (0.05 log units) below the measured one; the measured number falls inside the stated range.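

In this assay, the aromatic carbon para to a large group now has its first readable step: acetyl in place of 2-(ethoxycarbonyl)ethenyl gives a 2.3-fold higher number from compound 2 to compound 3 (0.36 log units; beyond the scatter). The effect therefore stays measurable, with only a modest loss, when a group of 7 heavy atoms with 2 double bonds gives way to one of 3 heavy atoms with 1 double bond, so the full length of the larger group is not required for activity in this assay. At the amide-type nitrogen, 4-acetylphenyl in place of carboxymethyl gives an at least 6.4-fold lower number from compound 1 to compound 3 (0.80 log units; beyond the scatter), but the true size of this gain remains unknown, since compound 1 stands at a limit of the assay and not at a number: the limit of > 25000 nM in this assay, at which 1 of the 3 values shown sits.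

Among these compounds, with only two groups compared at the aromatic carbon, it remains open what an amine, a nitrile or a carboxylic acid would do there. The numbers also give no reason for either step, and a single pair cannot show whether the exchange of acetyl for 2-(ethoxycarbonyl)ethenyl would have a similar size on a different core.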